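Swapping the furan of compound 3 for a thiophene

The compounds below may be only part of what the source reports. "The series", "measured", "known", "first", "only" and "open" are said of these compounds alone.

Compound 1 `O=C(Nc1ccc(-c2nccs2)cc1)C1CCCN(Cc2ccc(F)c(F)c2)C1`: 800 nM
Compound 2 `O=C(Nc1ccc(-c2ccoc2)cc1)C1CCCN(Cc2ccc(F)c(F)c2)C1`: 3000 nM
Compound 3 `O=C(Nc1ccc(-c2ccco2)cc1)C1CCCN(Cc2ccc(F)c(F)c2)C1`: 2200 nM

These three compounds share one core and differ only in the five-membered aromatic ring it carries. In a functional assay on A-375 cells (Homo sapiens) for activation, with a stated time of 3 days (a lower number here means that less compound is needed, a higher number that more compound is needed for the effect), compound 3 gives 2200 nM. Its gap to the furan-3-yl compound is small: a 1.4-fold lower number from compound 2 to compound 3 (0.13 log units; within the scatter). Its gap to the 1,3-thiazol-2-yl compound is clearer: a 2.8-fold higher number from compound 1 to compound 3 (0.44 log units; beyond the scatter). The other furan shows a similar gap: a 3.8-fold higher number from compound 1 to compound 2 (0.57 log units; beyond the scatter).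

Compound 4 `O=C(Nc1ccc(-c2cccs2)cc1)C1CCCN(Cc2ccc(F)c(F)c2)C1` has thiophen-2-yl in place of furan-2-yl on an aromatic carbon. Within the data shown here, no measured step makes this exact swap. The nearest guide is compound 1, whose ring also contains sulfur and which sits lower, as a 2.8-fold higher number from compound 1 to compound 3 (0.44 log units; beyond the scatter) shows. A small move towards a lower number is therefore expected in this assay, smaller than that step and perhaps within the scatter. The expected change is a 1.7-fold lower number from compound 3 to compound 4 (0.23 log units; within the scatter). The estimate for compound 4 is 1300 nM, with an expected range of 500 nM to 3300 nM.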

Compound 4, half-maximal effective concentration: 530 nM
Estimate against measurement, compound 4: 2.5-fold (0.39 log units) above; low and high end bracket the measured number.
By their numbers in this assay, from the lowest: compounds 4 and 1 (each within the scatter of the next); then compounds 3 and 2 (each within the scatter of the next).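

In this assay, among these compounds, sulfur in place of oxygen in the five-membered ring matters more than the earlier compounds could show, as the direct swap gives (a 4.2-fold lower number from compound 3 to compound 4 (0.62 log units; beyond the scatter)) and the comparison with the other furan gives (a 5.7-fold lower number from compound 2 to compound 4 (0.75 log units; beyond the scatter)). Compound 4 cannot be separated from compound 1 (a 1.5-fold lower number from compound 1 to compound 4 (0.18 log units; within the scatter)), so among these four compounds the two sulfur-containing rings, thiophen-2-yl and 1,3-thiazol-2-yl, stand together at lower numbers than both furans, with no compound going against this. Nothing available here explains why sulfur has this effect.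

Still open, going by these compounds, is whether thiophen-3-yl would match thiophen-2-yl, as the two furans match each other. Also open, on these data alone, is whether sulfur is needed at all, or whether a six-membered ring such as phenyl or pyridin-3-yl would give similarly low numbers at this position.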